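The compounds below may be only part of what the source reports. "The series", "measured", "known", "first", "only" and "open" are said of these compounds alone.

Compound 1 `COc1ccc(NC(=O)c2ncc(-c3cc(OC)c(OC)c(OC)c3)o2)cc1`: 25800 nM
Compound 2 `O=C(Nc1cccc(O)c1)c1ncc(-c2ccccc2)o1`: > 30000 nM

Both readings come from a functional assay on A549 cells (Homo sapiens) for cytotoxicity, read by CCK-8 assay; on this read-out lower numbers stand for stronger inhibition and higher numbers for weaker inhibition. Compound 2 stands at > 30000 nM, which is a limit of the assay and not a number. Compound 3 `Cc1ccc(NC(=O)c2ncc(-c3ccccc3)o2)cc1` has 4-methylphenyl in place of 3-hydroxyphenyl on an amide-type nitrogen. Among the compounds with values here, no measured step covers this change, so no step beyond the scatter is expected in this assay. Within the data shown here, the only numeric reading is that of compound 1, at 25800 nM, and the expectation stays in that region. The estimate for compound 3 is 30000 nM, with an expected range of 14000 nM to 60000 nM.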

Compound 3, half-maximal inhibitory concentration: > 30000 nM
Compound 3: no number, only a limit; the forecaster's own chance of this, stated with the estimate: 60%; the middle value lies on the limit itself.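

No step can be read from compound 2 to compound 3, since both readings are limits of the assay and not numbers: the limit of > 30000 nM in this assay, at which 2 of the 3 values shown sit. Still open, going by these compounds, is whether 4-methylphenyl in place of 3-hydroxyphenyl on an amide-type nitrogen shifts the read-out at all.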